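The compounds below may be only part of what the source reports. "The series", "measured", "known", "first", "only" and "open" are said of these compounds alone.

Of the compounds shown here, three sharing one core have been tested in an assay on isolated protein (Cricetulus griseus) for binding affinity to Alpha-1B adrenergic receptor (Mesocricetus auratus), read by radioligand binding; a lower number here means a stronger inhibitor, a higher number a weaker inhibitor. Compound 1, `CS(=O)(=O)Nc1ccc(Cl)c2c1CCCC2c1c[nH]cn1`, carries a chloro group on its aromatic ring. In this assay compound 1 gives < 10000 nM, which is a limit of the assay rather than a number. Compound 2, `CCS(=O)(=O)Nc1cccc2c1CCCC2(O)c1c[nH]cn1`, is measured in this assay at < 10000 nM, again only a limit. Compound 3, `CS(=O)(=O)Nc1ccc(O)c2c1CCCC2c1c[nH]cn1`, has hydroxy in place of chloro on the aromatic carbon of compound 1. In this assay compound 3 gives < 10000 nM, also a limit. The step that the two limits leave unreadable from compound 1 to compound 3 therefore cannot be read from these numbers. the limit of < 10000 nM in this assay, at which 3 of the 3 values shown sit: all three values sit at the same limit, so compound 3 stands at that limit and no order among the three compounds can be stated.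

Compound 4, `CS(=O)(=O)Nc1ccc(F)c2c1CCCC2c1c[nH]cn1`, differs from compound 3 in one place: fluoro in place of hydroxy on an aromatic carbon. Among the compounds with values here, no measured step bears on this change, since the only step between measured compounds is unreadable. In this assay, within the data shown here, the expectation for compound 4 is therefore only that its value stays under the limit, with no direction readable. The step that the limit leaves unreadable from compound 3 to compound 4 is the estimated change. The estimate for compound 4 is 1000 nM, between 50 nM and 9000 nM.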

Compound 4, inhibition constant: < 10000 nM
Compound 4 ended at the assay's limit; the forecaster's own chance of this, stated with the estimate: 60%; the middle value lies beyond the limit too.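

In this assay compound 4 gives < 10000 nM, a limit of the assay and not a number. The steps joining compound 4 to compound 1 and compound 3 therefore cannot be read, and all the compounds share one reading: the limit of < 10000 nM in this assay, at which 4 of the 4 values shown sit.

The compounds shown leave open how fluoro, chloro and hydroxy on that aromatic carbon rank against one another.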